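The source may hold more compounds than are shown below. What is called first, only, known or untested is meant among the compounds shown, and "the series" means these compounds.

Series notes. The shared core carries an acetylated sulfonamide and a phenyl; only the third substituent varies. Compound 1 `COc1ccc(OC)c(-c2cc(-c3ccccc3)nn2-c2ccc(S(=O)(=O)NC(C)=O)cc2)c1` in a functional assay on cells (Cancer cell lines, Homo sapiens) for cytotoxicity, read by sulforhodamine B assay, with a stated time of 48 h (a lower number here means a stronger inhibitor of growth, a higher number a weaker inhibitor of growth), gives 44500 nM. Compound 2 `CC(=O)NS(=O)(=O)c1ccc(-n2nc(-c3ccccc3)cc2-c2cc(O)ccc2O)cc1` gives 100000 nM in this assay, and compound 3 `CC(=O)NS(=O)(=O)c1ccc(-n2nc(-c3ccc(Cl)cc3)cc2-c2cc(O)ccc2O)cc1` gives 82100 nM. Compound 2 stands at the highest of the three numbers, though its gap to compound 3 is within the scatter: the step of a 2.2-fold higher number from compound 1 to compound 2 (0.35 log units; beyond the scatter) is modest and beyond the scatter, whereas a 1.2-fold lower number from compound 2 to compound 3 (0.09 log units; within the scatter) lies within it, so compound 2 and compound 3 cannot be ordered.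

Compound 4 `CC(=O)NS(=O)(=O)c1ccc(-n2nc(-c3ccccc3)cc2C2=CC(=O)C=CC2=O)cc1` is not yet measured. Relative to compound 2 it carries a group of 8 heavy atoms (6 carbon, 2 oxygen; one six-membered non-aromatic ring of carbon only) in place of a group of 8 heavy atoms (6 carbon, 2 oxygen; one six-membered aromatic ring of carbon only), on an aromatic carbon. Going by the values given here, neither measured step matches this change: one exchanged methoxy for hydroxy, the other added a chloro, and no step in the set exchanges an aromatic ring for a non-aromatic one or removes both hydrogen-bond donors. The data therefore give no direct anchor, and the expectation rests only on the spread of the three numbers, which all sit at the high end of this assay. A step of a 2.5-fold lower number from compound 2 to compound 4 (0.40 log units; beyond the scatter) is estimated, toward a lower number, held loosely. Compound 4 is expected at 40000 nM, within 10000 nM to 100000 nM.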

Compound 4, concentration for total growth inhibition: 100000 nM
Compound 4: the middle estimate sits 2.5-fold (0.40 log units) below what was measured; the measured number falls inside the stated range.
By their numbers in this assay, from the lowest: compounds 1, 3, 2 and 4 (each within the scatter of the next, the first and the last beyond it).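

At this position, on an aromatic carbon of the five-membered ring, the 2,5-dihydroxyphenyl group of compound 2 can be exchanged for the non-aromatic six-membered ring of compound 4, which has 0 hydrogen-bond donors where the group it replaces has 2, and this assay shows no change at the digits printed from compound 2 to compound 4 (within the scatter). Aromaticity of this ring and the presence of these donors therefore make no difference that can be read in this pair, and the comparison with the 2,5-dimethoxyphenyl group gives a 2.2-fold higher number from compound 1 to compound 4 (0.35 log units; beyond the scatter), the same modest size as a 2.2-fold higher number from compound 1 to compound 2 (0.35 log units; beyond the scatter). No measurement at hand accounts for this result or for the gap to compound 1.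

Still open, from the compounds shown here alone, is whether the flat result for compound 2 and compound 4 holds for other groups at this position, such as a 2,5-diaminophenyl ring or a phenyl bearing a carboxylic acid. Going by these compounds alone, also open is whether the chloro of compound 3, placed on the phenyl of compound 4, would move the number in this assay, since the chloro step so far has been read only with the 2,5-dihydroxyphenyl group.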